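This account rests on a few compounds, and the source may have more. Where it says the series, first, only, none or still open, it means among the compounds named here.

Of the compounds shown here, two sharing one core have been tested in a functional assay on U-87MG ATCC cells for antiproliferative activity against U-87 MG (Homo sapiens), read by MTT assay, with a stated time of 72 h; a lower number here means a stronger inhibitor, a higher number a weaker inhibitor. Among the compounds with values here, compound 2 `Cc1nn(C)c(Oc2ccc(F)cc2)c1/C=N\CCCCCCOc1cc2oc(=O)cc(C)c2cc1Cl` gives 16700 nM in this assay, and this is the only number recorded. Compound 1 `Cc1nn(C)c(Oc2ccc(F)cc2)c1/C=N\CCCCCOc1cc2oc(=O)cc(C)c2cc1Cl` gives > 25000 nM in this assay, which is a limit of the assay rather than a number; this stands as the limit of > 25000 nM in this assay, at which 1 of the 2 values shown sits. Within the data shown here, no step between measured compounds that differ in one place is available, so the pair shows only that compound 2 yields a number where compound 1 yields a limit.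

Compound 3 `Cc1nn(C)c(Oc2ccc(Br)cc2)c1/C=N\CCCCCCOc1cc2oc(=O)cc(C)c2cc1Cl` differs from compound 2 in a single place: bromo in place of fluoro on an aromatic carbon, para to a large group. Among the measured compounds shown here, nothing among the measured compounds tells how such a halogen swap behaves here, so the expectation rests on the size of the change alone. The expected step from compound 2 to compound 3 is a 1.1-fold lower number from compound 2 to compound 3 (0.05 log units; within the scatter), none beyond the scatter. Compound 3 is therefore estimated at 15000 nM in this assay, with a range from 6000 nM to 40000 nM.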

Compound 3, half-maximal inhibitory concentration: 5420 nM
For compound 3 the middle estimate is 2.8-fold (0.44 log units) above the measured one, outside the stated range (below it).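

Exchanging fluoro for bromo, which turns the 4-fluorophenoxy group into a 4-bromophenoxy group, gives a 3.1-fold lower number from compound 2 to compound 3 (0.49 log units; beyond the scatter) in this assay. Within the data shown here, this is the first readable step at this position on the aromatic ring, and it shows that the position responds: one heavy atom replaces one heavy atom, no ring, hydrogen-bond donor, hydrogen-bond acceptor or charge enters or leaves, and the number still moves beyond the usual scatter. The step is modest and rests on a single pair, so it describes this one halogen swap on this one compound and sets no rule for halogens in general.

Going by these compounds, whether chloro, a methoxy group or an amine at the same place would lower the number further remains open, as does whether bromo would have a similar effect on the chain of compound 1. Compound 1 offers no number for such a comparison, since its result is a limit of the assay: the limit of > 25000 nM in this assay, at which 1 of the 3 values shown sits.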